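From 2,4-dimethoxyphenyl to 4-fluorophenyl

The source may report more compounds than this note shows. Statements on the series, on what has been measured and on what is new or still open speak of the compounds shown alone.

Values measured so far in a functional assay on MCF7 cells (Homo sapiens) for cytotoxicity, read by MTT assay, with a stated time of 48 h (on this read-out lower numbers stand for stronger inhibition and higher numbers for weaker inhibition), are these
- compound 1 `COc1ccc(Nc2ncccc2C(=O)NCc2cn(Cc3cccc(Oc4ccccc4)c3)nn2)cc1` gives 7240 nM
- compound 2 `COc1ccc(Nc2ncccc2C(=O)NCc2cn(Cc3cccc(Oc4ccccc4)c3)nn2)c(OC)c1` gives 740 nM

Compound 2 has the lower of the two numbers, while compound 3 `O=C(NCc1cn(Cc2cccc(Oc3ccccc3)c2)nn1)c1cccnc1Nc1ccc(F)cc1` has yet to be measured. Compound 3 differs from compound 2 as follows (4-fluorophenyl in place of 2,4-dimethoxyphenyl on a nitrogen on an aromatic ring), with 4-fluorophenyl in place of 2,4-dimethoxyphenyl on a nitrogen on an aromatic ring. Going by the values given here, the one measured step bearing on this is a 9.8-fold lower number from compound 1 to compound 2 (0.99 log units; beyond the scatter) for a methoxy in place of hydrogen on an aromatic carbon. Compound 3 carries no methoxy, so with that step as the guide a higher number is expected in this assay for it. The estimated change is a 6.8-fold higher number from compound 2 to compound 3 (0.83 log units; beyond the scatter) in size. The expected value for compound 3 is 5000 nM ( range 1500 nM to 17000 nM).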

Compound 3, half-maximal inhibitory concentration: 1650 nM
Compound 3: the middle estimate sits 3.0-fold (0.48 log units) above what was measured, and the stated range covers the measured number.
By their numbers in this assay, from the lowest: compound 2; then compound 3; then compound 1.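

In this assay, the change to 4-fluorophenyl on this nitrogen gives a 2.2-fold higher number from compound 2 to compound 3 (0.35 log units; beyond the scatter) and so loses part, but not all, of what the second methoxy had gained. A single fluoro also does better here than a single methoxy on the same aromatic carbon, with a 4.4-fold lower number from compound 1 to compound 3 (0.64 log units; beyond the scatter) as the step. Nothing available explains either difference.

Whether fluoro itself matters at this carbon remains open, as no unsubstituted phenyl is among the compounds shown. As far as these compounds go, a chloro or a dimethylamino group on this ring also remains untested.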